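The source may hold more compounds than are shown below. What is called first, only, known or untested is meant among the compounds shown, and "the series" means these compounds.

Working notes on the series. Of the compounds shown here, three have been tested in a functional assay on COLO 205 cells (Homo sapiens) for inhibition, read by sulforhodamine B assay, with a stated time of 48 h, tested at 50 uM; a higher number here means more inhibition of growth at the concentration tested, a lower number less inhibition of growth. Compound 1 `COc1cc(/C=C/C(=O)/C=C/c2ccccc2)ccc1OCc1cn(CCCCCOc2cc(=O)oc3ccccc23)nn1` gives 22%. Compound 3 `COc1cc(/C=C/C(=O)/C=C/c2cccc3ccccc23)ccc1OCc1cn(CCCCCOc2cc(=O)oc3ccccc23)nn1` gives 40%, and the change from compound 1 to compound 3, naphthalen-1-yl in place of phenyl on a double-bonded chain carbon bound to a double-bonded chain carbon, carries a number 18 percentage points higher from compound 1 to compound 3 (beyond the scatter). Compound 2 `COc1cc(/C=C/C(=O)/C=C/c2ccco2)ccc1OCc1cn(CCCCOc2cc(=O)oc3ccccc23)nn1` gives 43%; of the three numbers it is the largest, with the gap to compound 3 within the scatter and the gap to compound 1 beyond it. Compound 2 and compound 1 differ in more than one place, so only their two values are on record.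

Compound 4 `COc1cc(/C=C/C(=O)/C=C/c2cc(OC)c(OC)c(OC)c2)ccc1OCc1cn(CCCCOc2cc(=O)oc3ccccc23)nn1` is not yet measured. Its difference from compound 2 is 3,4,5-trimethoxyphenyl in place of furan-2-yl on a double-bonded chain carbon bound to a double-bonded chain carbon. Going by the values given here, the one measured step at this place, from compound 1 to compound 3, was modest in size and upward. The new swap is a different one, so its direction cannot be taken from that step; no step beyond the scatter is expected. For compound 4 the number expected in this assay is 42%, within 25% to 60%, a step of a number 1 percentage points lower from compound 2 to compound 4 (within the scatter).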

Compound 4, percent growth inhibition at one concentration: 60%
Estimate against measurement, compound 4: 18 percentage points below; low and high end bracket the measured number.
By their numbers in this assay, from the lowest: compound 1; then compounds 3 and 2 (each within the scatter of the next); then compound 4.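

In this assay the swap of furan-2-yl for 3,4,5-trimethoxyphenyl gives a number 17 percentage points higher from compound 2 to compound 4 (beyond the scatter), so the group on a double-bonded chain carbon bound to a double-bonded chain carbon changes the number in a second pair of compounds, alongside a number 18 percentage points higher from compound 1 to compound 3 (beyond the scatter). Here the entering group differs from the leaving one in ring size, heavy atoms and hydrogen-bond acceptors all at once, so this single pair cannot separate those changes. Nothing on record accounts for the size or direction of this step.

Still open, as far as these compounds go, is whether a phenyl ring carrying a single methoxy group or a dimethylamino group at this place would give a similar number. Also open, from the compounds shown here alone, is whether 3,4,5-trimethoxyphenyl would carry a similar step on the longer chain of compound 1.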